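This account rests on a few compounds, and the source may have more. Where it says the series, first, only, none or still open, it means among the compounds named here.

Compound 2, with the structure `CC(=O)OCCSC[C@@H]1CN(C)CC[C@H]1c1ccc(Cl)cc1`, gives 536 nM in an assay on a subcellular fraction from brain with sodium-dependent dopamine transporter (Rattus norvegicus) as the target (a lower number here means a stronger inhibitor, a higher number a weaker inhibitor), the highest of the two numbers recorded there; its nearest neighbour is compound 1, structure `CC(=O)OCCSC[C@H]1CN(C)CC[C@H]1c1ccc(Cl)cc1`, which gives 177 nM. For the measured compounds named here, the one measured step, a 3.0-fold higher number from compound 1 to compound 2 (0.48 log units; beyond the scatter), rests on (the fact that compounds 1 and 2 differ only in the configuration as drawn). Compound 3, structure `CC(=O)OCCSC[C@@H]1CN(C)CC[C@@H]1c1ccc(Cl)cc1`, has not yet been measured, and it differs from compound 2 only as follows: the two compounds have the same atoms and bonds and differ only in configuration as drawn: 1 of 2 stereo elements differ; a stereocentre at a saturated ring carbon is drawn R in compound 2 and S in compound 3. Going by the values given here, this is the second of the two stereocentres, not the one that separates compound 1 from compound 2, so the single measured step shows only that a change at one stereocentre of this core can shift the number modestly; it does not show the direction for this other centre. Compound 3 is therefore expected to fall near compound 2, with a wide range and no clear direction, as a 1.2-fold lower number from compound 2 to compound 3 (0.08 log units; within the scatter). The estimate for compound 3 is 450 nM, between 120 nM and 1700 nM.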

Compound 3, inhibition constant: 46 nM
For compound 3 the middle estimate is 9.8-fold (0.99 log units) above the measured one, outside the stated range (below it).
By their numbers in this assay, from the lowest: compound 3; then compound 1; then compound 2.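

In this assay, inverting the second stereocentre alone gives a 12-fold lower number from compound 2 to compound 3 (1.07 log units; beyond the scatter), so this centre can move the number further than the modest step seen earlier at the other stereocentre. Inverting both centres, which yields the mirror image, gives a 3.8-fold lower number from compound 1 to compound 3 (0.59 log units; beyond the scatter), leaving compound 3 as the strongest inhibitor of the three, with its steps to both others beyond the scatter. The comparison with compound 2 involves configuration and nothing else: the fact that compounds 2 and 3 differ only in the configuration as drawn.

On these data alone, the fourth combination of the two stereocentres remains open, so the effect of this centre is known only with the other centre as drawn in compound 2. Also open, as far as these compounds go, is whether the same preference holds with a free hydroxyl in place of the acetate ester, or with fluorine in place of the chlorine.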